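This account rests on a few compounds, and the source may have more. Where it says the series, first, only, none or still open, it means among the compounds named here.

- Compound 1 `COc1ccc(Cc2nnc(NC(=O)/C(C#N)=C/c3ccccc3OS(=O)(=O)c3ccccc3[N+](=O)[O-])s2)cc1`: 68%
- Compound 2 `N#C/C(=C\c1ccccc1OS(=O)(=O)c1ccc([N+](=O)[O-])cc1)C(=O)Nc1nnc(Cc2cccc(F)c2)s1`: 65%
- Compound 3 `N#C/C(=C\c1ccccc1OS(=O)(=O)c1ccccc1[N+](=O)[O-])C(=O)Nc1nnc(Cc2cccc(F)c2)s1`: 68%

In a functional assay on RS4-11 cells (Homo sapiens) for inhibition, read by CCK-8 assay, with a stated time of 48 h, tested at 20 uM (a higher number here means more inhibition of growth at the concentration tested, a lower number less inhibition of growth), compound 3 gives 68%, level with compound 1 and the joint highest of the three numbers, though all three lie within the scatter of one another. Compound 4 `N#C/C(=C\c1ccccc1OS(=O)(=O)c1ccccc1[N+](=O)[O-])C(=O)Nc1nnc(Cc2ccc(Cl)cc2)s1` differs from compound 3 by 4-chlorophenyl in place of 3-fluorophenyl on a saturated chain carbon bound to an aromatic carbon. Among the compounds with values here, the one measured swap at this place gave no change at the digits printed from compound 1 to compound 3 (within the scatter). A swap elsewhere, on the sulfonyl sulfur, gave a number 3 percentage points higher from compound 2 to compound 3 (within the scatter). Neither step offers a reason to expect a real shift, so the expected step is a number 2 percentage points lower from compound 3 to compound 4 (within the scatter), none beyond the scatter. Compound 4 is estimated at 66%, with an expected range of 52% to 78%.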

Compound 4, percent growth inhibition at one concentration: 65%
Compound 4: middle estimate off by 1 percentage points, on the high side, and the stated range covers the measured number.
By their numbers in this assay, from the lowest: compounds 2, 4, 1 and 3 (each within the scatter of the next).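

In this assay, the new aromatic ring gives a number 3 percentage points lower from compound 3 to compound 4 (within the scatter), and the swap of chloro for methoxy on an aromatic carbon gives a number 3 percentage points lower from compound 1 to compound 4 (within the scatter). With 4-methoxyphenyl, 3-fluorophenyl and 4-chlorophenyl all within the scatter of one another, this position has now accepted a chlorine as well as a fluorine or a methoxy without a readable change in these compounds. Nothing available explains this sameness. Still open, from the compounds shown here alone, is whether a phenyl ring carrying an amine or a carboxylic acid would hold this level. Going by these compounds, a longer chain between the ring and the core is equally open.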